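Clearance shift on swapping the aryl sulfur group

The source may hold more compounds than are shown below. What is called first, only, known or untested is meant among the compounds shown, and "the series" means these compounds.

Compound 3 `CC#C[C@H]1CN(S(=O)(=O)c2ccc(N)nc2)CCN1c1ccc(S(=O)(=O)NCC2CC2)cc1` gives 213 mL.min-1.g-1 in an ADME assay (liver) for metabolic stability, with Liver microsome (Rattus norvegicus) as the target, using microsomes and NADPH, with a stated time of 30 min; a lower number here means slower removal, a higher number faster removal of the compound. Of the three measured numbers, the step of a 2.3-fold higher number from compound 1 to compound 3 (0.36 log units; beyond the scatter) from compound 1 `CC#C[C@H]1CN(S(=O)(=O)c2ccc(N)nc2)CCN1c1ccc(C(O)(COC)C(F)(F)F)cc1`, which gives 93 mL.min-1.g-1, is beyond the scatter, whereas the step of a 1.9-fold higher number from compound 2 to compound 3 (0.27 log units; within the scatter) from compound 2 `CC#CCC(O)(c1ccc(N2CCN(S(=O)(=O)c3ccc(N)nc3)C[C@@H]2C#CC)cc1)C(F)(F)F`, which gives 115 mL.min-1.g-1, is within it, so compound 3 and compound 2 are not separated by this assay. The step of a 1.2-fold higher number from compound 1 to compound 2 (0.09 log units; within the scatter) does not touch the position changed here.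

Compound 4 `CC#C[C@H]1CN(S(=O)(=O)c2ccc(N)nc2)CCN1c1ccc(S(=N)(=O)C2CC2)cc1` differs from compound 3 by a group of 6 heavy atoms (3 carbon, 1 nitrogen, 1 oxygen, 1 sulfur; one three-membered non-aromatic ring of carbon only) in place of a group of 8 heavy atoms (4 carbon, 1 nitrogen, 2 oxygen, 1 sulfur; one three-membered non-aromatic ring of carbon only), on an aromatic carbon. For the measured compounds named here, no measured pair alters this group while keeping the rest fixed; the only steps at this aromatic carbon replace the whole group and move the number modestly, as in the step from compound 1 to compound 3. Similar structure and retained donor and acceptor counts argue for a step in this assay that is expected to stay within the scatter, with no preferred direction, a 1.3-fold lower number from compound 3 to compound 4 (0.10 log units; within the scatter). Compound 4 is therefore estimated at 170 mL.min-1.g-1, with a range of 80 mL.min-1.g-1 to 340 mL.min-1.g-1.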

Compound 4, intrinsic clearance in microsomes: 23 mL.min-1.g-1
Compound 4: middle estimate off by 7.4-fold (0.87 log units), on the high side, and the stated range ends above it.
By their numbers in this assay, from the lowest: compound 4; then compounds 1, 2 and 3 (each within the scatter of the next, the first and the last beyond it).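

In this assay, for the compounds shown here, the group on this aromatic carbon matters more than the earlier compounds indicated: replacing (cyclopropylmethyl)sulfamoyl with the group of compound 4 gives a 9.3-fold lower number from compound 3 to compound 4 (0.97 log units; beyond the scatter) even though the hydrogen-bond donor and acceptor counts of the two groups match. Going by these compounds alone, the same group also sits apart from those of the other two compounds, with a 5.0-fold lower number from compound 2 to compound 4 (0.70 log units; beyond the scatter) and a 4.0-fold lower number from compound 1 to compound 4 (0.61 log units; beyond the scatter), so all three steps to compound 4 run toward a lower number and each is larger than the earlier steps at this carbon. Nothing available here accounts for the size of these steps.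

The compounds shown do not separate the change at the sulfur from the loss of the methylene of the cyclopropylmethyl chain. From the compounds shown here alone, whether the low number survives a methyl or tert-butyl group in place of the cyclopropyl ring, or a simple amine on this aromatic carbon, remains open.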